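From Methyl to Ethyl on an Aromatic Nitrogen

The source may report more compounds than this note shows. Statements on the series, on what has been measured and on what is new or still open speak of the compounds shown alone.

Compound 1 `Cc1ccc(C(=O)Nc2cccc(C(F)(F)F)c2)cc1-c1ccc2c(-c3cn[nH]c3)n[nH]c2c1`: > 1000 nM, a limit of the assay
Compound 2 `Cc1ccc(C(=O)Nc2cccc(C(F)(F)F)c2)cc1-c1ccc2c(-c3cnn(C)c3)n[nH]c2c1`: 24.3 nM

Both compounds were tested in a functional assay on NCI-H2286 cells (Homo sapiens) for antiproliferative activity, read by CCK-8 assay, with a stated time of 72 h; a lower number here means a stronger inhibitor, a higher number a weaker inhibitor. For the measured compounds named here, compound 2, at 24.3 nM, holds the only actual number so far. Compound 1 reaches only a limit of the assay, > 1000 nM, as the limit of > 1000 nM in this assay, at which 1 of the 2 values shown sits, records.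

Compound 3 `CCn1cc(-c2n[nH]c3cc(-c4cc(C(=O)Nc5cccc(C(F)(F)F)c5)ccc4C)ccc23)cn1` differs from compound 2 in one place: methyl in place of hydrogen on a saturated chain carbon bound to an aromatic nitrogen. This is methyl in place of hydrogen on a saturated chain carbon bound to an aromatic nitrogen, turning 1-methyl-1H-pyrazol-4-yl into 1-ethyl-1H-pyrazol-4-yl.

Going by the values given here, one measured step bears on this change, an at least 41-fold lower number from compound 1 to compound 2 (1.61 log units; beyond the scatter), where methyl replaced hydrogen on an aromatic nitrogen. That step was large and lies beyond the scatter. However, it put a group onto a bare nitrogen, whereas the new change only extends a group already present, so it sets no size for the new step. A much smaller effect is therefore expected, with a slight lean towards weaker inhibition. The expected step is a 1.3-fold higher number from compound 2 to compound 3 (0.12 log units; within the scatter), close to the scatter. For compound 3 the estimated value is 32 nM, expected to fall between 11 nM and 130 nM.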

Compound 3, half-maximal inhibitory concentration: 19.8 nM
Beside the measured number, compound 3's estimate is 1.6-fold (0.21 log units) above it, and the stated range covers the measured number.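

In this assay, going from methyl to ethyl on the aromatic nitrogen gives a 1.2-fold lower number from compound 2 to compound 3 (0.09 log units; within the scatter), so this position takes the added methyl on the saturated chain carbon with no change that can be told from the scatter. With ethyl in place of hydrogen on the aromatic nitrogen, the result is an at least 50-fold lower number from compound 1 to compound 3 (1.70 log units; beyond the scatter), a large step like the earlier at least 41-fold lower number from compound 1 to compound 2 (1.61 log units; beyond the scatter), so across these three compounds the large difference lies between the bare nitrogen and either group on it, not between methyl and ethyl. Compound 1 sits at a limit of the assay and not at a number, so both of these large steps give only a bound on their size: the limit of > 1000 nM in this assay, at which 1 of the 3 values shown sits.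

The compounds shown leave open how far this reach extends, whether a longer chain such as propyl, or a chain ending in an amine or a carboxylic acid, would stay as close to compound 2 as ethyl does. They also speak only to this assay, and so cannot tell whether methyl and ethyl would remain this close in any other setting.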